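Halogen Position on the Benzyl Ether: Chlorine to Fluorine

The compounds below may be only part of what the source reports. "The series", "measured", "known", "first", "only" and "open" are said of these compounds alone.

Compound 1 `Cc1ccc(NC(=S)NC(=O)c2ccc(OCc3ccccc3F)cc2)cc1-c1nc2ccccc2[nH]1`: 1870 nM
Compound 2 `Cc1ccc(NC(=S)NC(=O)c2ccc(OCc3cccc(F)c3)cc2)cc1-c1nc2ccccc2[nH]1`: 55300 nM
Compound 3 `Cc1ccc(NC(=O)NC(=O)c2ccc(OCc3cccc(Cl)c3)cc2)cc1-c1nc2ccccc2[nH]1`: 15400 nM

In a functional assay on HT-29 cells (Homo sapiens) for inhibition, read by MTT assay, with a stated time of 48 h (on this read-out lower numbers stand for stronger inhibition and higher numbers for weaker inhibition), compound 1 gives 1870 nM, compound 2 gives 55300 nM and compound 3 gives 15400 nM. Compound 3 thus stands second highest of the three numbers, above compound 1 and below compound 2.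

Compound 4, `Cc1ccc(NC(=O)NC(=O)c2ccc(OCc3ccc(F)cc3)cc2)cc1-c1nc2ccccc2[nH]1`, has not yet been measured in this assay. It differs from compound 3 in one place: 4-fluorophenyl in place of 3-chlorophenyl on a saturated chain carbon bound to an oxygen on an aromatic ring.

Within the data shown here, only one measured step touches the same region of the molecule, a 30-fold higher number from compound 1 to compound 2 (1.47 log units; beyond the scatter), and it shows that shifting a halogen from one position of the benzyl ring to another can move the number greatly. That step, however, compares two other positions, and compounds 1 and 2 share a core that is not the core of compound 3 and compound 4. Among the measured compounds shown here, no measured pair sets 3-chlorophenyl against 4-fluorophenyl, and no measured compound carries a halogen in the 4-position. The direction of the change cannot be read from the data, so a wide range is expected.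

Compound 4 is expected to give about 12000 nM in this assay, most likely between 2500 nM and 60000 nM. This estimate corresponds to an expected step of a 1.3-fold lower number from compound 3 to compound 4 (0.11 log units; within the scatter), little beyond the scatter in either direction.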

Compound 4, half-maximal inhibitory concentration: 980 nM
Estimate against measurement, compound 4: 12-fold (1.09 log units) above; the measured number lies below the stated range.
By their numbers in this assay, from the lowest: compounds 4 and 1 (each within the scatter of the next); then compound 3; then compound 2.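

In this assay, 4-fluorophenyl in place of 3-chlorophenyl on a saturated chain carbon bound to an oxygen on an aromatic ring gives a 16-fold lower number from compound 3 to compound 4 (1.20 log units; beyond the scatter), a large step beyond the scatter, so this place also responds strongly on the core of compound 3 and not only on the core of compound 1. The earlier step, a 30-fold higher number from compound 1 to compound 2 (1.47 log units; beyond the scatter), concerned fluorine alone, whereas the new step changes the halogen and its position together; in both pairs, the partner carrying 3-fluorophenyl or 3-chlorophenyl gives the higher number, and neither pair goes against this. No measurement offered here explains the size of either step.

The compounds shown leave open how much of the new step belongs to the halogen and how much to its position, as 3-fluorophenyl and 4-chlorophenyl do not appear on the core of compound 3. Also open, as far as these compounds go, is how 4-fluorophenyl would read on the core of compound 1, and whether a methoxy group or a nitrile on the benzyl ring would hold the lower number.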